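A Nitro for a Bromine on the Chalcone Arm

The source may hold more compounds than are shown below. What is called first, only, known or untested is meant among the compounds shown, and "the series" means these compounds.

Measured compounds:
compound 1, `O=C(COc1ccc(C(=O)/C=C/c2ccccc2Br)cc1)N[C@H]1CCOC1=O`, 12200 nM
compound 2, `O=C(CNc1cccc(Cl)c1)N[C@H]1CCOC1=O`, > 64000 nM
compound 3, `Cc1cc(Cl)ccc1NCC(=O)N[C@H]1CCOC1=O`, > 64000 nM

Among the compounds with values here, in a functional assay on MGC-803 cells (Homo sapiens) for antiproliferative activity, read by MTT assay, with a stated time of 72 h (a lower number here means a stronger inhibitor, a higher number a weaker inhibitor), compound 1 gives 12200 nM, the only real number among the three measured compounds. The other two results are the limit of > 64000 nM in this assay, at which 2 of the 3 values shown sit. For compound 2 the result is a limit, > 64000 nM, not a number. Compound 3 likewise ends in a limit, > 64000 nM. Within the data shown here, no pair of measured compounds differs in a single place, so no measured step is available to guide the next compound.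

Compound 4, `O=C(COc1ccc(C(=O)/C=C/c2cccc([N+](=O)[O-])c2)cc1)N[C@H]1CCOC1=O`, keeps the core of compound 1 and changes one part: 3-nitrophenyl in place of 2-bromophenyl on a double-bonded chain carbon bound to a double-bonded chain carbon. Among the measured compounds shown here, with no measured step of this kind, the expected change in this assay from compound 1 to compound 4 is none beyond the scatter, in either direction. Compound 4 is therefore expected to give 10000 nM, with a plausible range from 3500 nM to 35000 nM, which means an estimated step of a 1.2-fold lower number from compound 1 to compound 4 (0.09 log units; within the scatter).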

Compound 4, half-maximal inhibitory concentration: > 64000 nM
Compound 4 was reported as a limit (the forecaster's own chance of this, stated with the estimate: 10%); middle value at least 6.4-fold (0.80 log units) from the limit.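

In this assay compound 4 gives > 64000 nM, which is a limit and not a number. Within the data shown here, this is the first step in the set that can be read between compounds differing in one place, and it shows that the group on a double-bonded chain carbon bound to a double-bonded chain carbon is not freely exchangeable: 3-nitrophenyl in place of 2-bromophenyl gives an at least 5.2-fold higher number from compound 1 to compound 4 (0.71 log units; beyond the scatter). The step has no upper end that can be read, and the only real number in the set still belongs to compound 1: the limit of > 64000 nM in this assay, at which 3 of the 4 values shown sit.

The two groups differ both in the substituent and in its place on the phenyl ring, so the compounds shown cannot separate these two changes. From the compounds shown here alone, whether an aminophenyl or a methoxyphenyl group at this place would give a real number remains open.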